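Amide versus urea on the shared core: compound 3 outlook

The source may report more compounds than this note shows. Statements on the series, on what has been measured and on what is new or still open speak of the compounds shown alone.

Measured so far:
compound 1 `O=C(Nc1ccc(-n2ccc3c(NC(=O)c4ccccc4)ncnc32)cc1)c1ccc(Cl)c(Cl)c1`: in an ADME assay on HS27 cells (Homo sapiens) for antiproliferative activity, read by MTT assay, with a stated time of 24 h (a lower number here means a stronger inhibitor, a higher number a weaker inhibitor), compound 1 gives 5000 nM.
compound 2 `O=C(Nc1ccc(-n2ccc3c(NC(=O)c4ccccc4)ncnc32)cc1)Nc1ccc(Cl)c(C(F)(F)F)c1`: in this assay compound 2 gives 6000 nM.

Compound 2 stands beside compound 1, the pair differing by a 1.2-fold higher number from compound 1 to compound 2 (0.08 log units; within the scatter), so neither is separated from the other. Compound 3 `O=C(Nc1ccc(-n2ccc3c(NC(=O)c4ccccc4)ncnc32)cc1)c1ccc(Cl)c(C(F)(F)F)c1` differs from compound 2 by 4-chloro-3-(trifluoromethyl)phenyl in place of (4-chloro-3-(trifluoromethyl)phenyl)amino on a carbonyl carbon. Among the measured compounds shown here, the only step that bears on it, the move from compound 1 to compound 2, changed both the linker and the aryl group at once and stayed within the scatter; no step isolates the linker alone. The expectation for compound 3 is therefore no step beyond the scatter, a 1.2-fold lower number from compound 2 to compound 3 (0.08 log units; within the scatter). Compound 3 is estimated at 5000 nM, within 2500 nM to 10000 nM.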

Compound 3, half-maximal inhibitory concentration: 5500 nM
Compound 3: middle estimate off by 1.1-fold (0.04 log units), on the low side, and the stated range covers the measured number.
By their numbers in this assay, from the lowest: compounds 1, 3 and 2 (each within the scatter of the next).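

With the aryl group held fixed, the urea-to-amide change alone, which removes the amino nitrogen and its hydrogen-bond donor, gives in this assay a 1.1-fold lower number from compound 2 to compound 3 (0.04 log units; within the scatter), so the linker on this carbonyl carbon is now isolated and separates nothing. On the amide side, the aryl change alone, trifluoromethyl in place of chloro on an aromatic carbon, gives a 1.1-fold higher number from compound 1 to compound 3 (0.04 log units; within the scatter). No measurement at hand offers an explanation for either step.

Open, going by these compounds, is whether an amine or a carboxylic acid on that phenyl ring would give a step beyond the scatter. Also open, on these data alone, is whether a replacement of the benzoyl amide on the shared core would do so.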